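The source may report more compounds than this note shows. Statements on the series, on what has been measured and on what is new or still open speak of the compounds shown alone.

The measured compounds:
Compound 1, `Fc1ccc(-c2cn3nc(Cc4ccc(Cl)cc4)sc3n2)cc1`: in a functional assay on L1210 cells (Mus musculus) for cytotoxicity, with a stated time of 48 h (a lower number here means a stronger inhibitor, a higher number a weaker inhibitor), compound 1 gives > 250000 nM, which is a limit of the assay and not a number.
Compound 2, `Cc1ccc(-c2cn3nc(Cc4ccc(Cl)cc4)sc3n2)cc1`: in this assay compound 2 gives > 250000 nM, again a limit of the assay.
Compound 3, `O=[N+]([O-])c1ccc(-c2cn3nc(Cc4ccc(Cl)cc4)sc3n2)cc1`: in this assay compound 3 gives 214000 nM.

Compound 3 is thus the only one of the three with a number; compounds 1 and 2 both sit at the limit of > 250000 nM in this assay, at which 2 of the 3 values shown sit. The steps to it are an at least 1.1-fold lower number from compound 1 to compound 3 (0.06 log units; that floor lies within the scatter) and an at least 1.1-fold lower number from compound 2 to compound 3 (0.06 log units; that floor lies within the scatter), and the step that the two limits leave unreadable from compound 1 to compound 2 stays unreadable. All three steps vary the group that in compound 3 is the nitro group.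

Compound 4, `N#CSc1c(-c2ccc([N+](=O)[O-])cc2)nc2sc(Cc3ccc(Cl)cc3)nn12`, differs from compound 3 by cyanosulfanyl in place of hydrogen on an aromatic carbon. Among the measured compounds shown here, no measured step touches that part of the shared core, so nothing measured here gives a size for this change. The expectation for compound 4 therefore rests on the change itself and is held loose: a step of a 3.6-fold lower number from compound 3 to compound 4 (0.55 log units; beyond the scatter) is expected, and compound 4 is estimated at 60000 nM, between 10000 nM and 250000 nM.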

Compound 4, half-maximal inhibitory concentration: 50000 nM
Compound 4: the middle estimate sits 1.2-fold (0.08 log units) above what was measured, within the range that was stated.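

In this assay, among the compounds shown here, the change from hydrogen to cyanosulfanyl on the aromatic carbon next to the ring atom that bears a 4-nitrophenyl group gives a 4.3-fold lower number from compound 3 to compound 4 (0.63 log units; beyond the scatter) and is the first step here with a full size beyond the scatter. For the compounds shown here, the earlier steps all varied the group that in compound 3 is the nitro group, so this is the first sign that this other position of the shared core can move the number at all. Those earlier steps gave only floors within the scatter or could not be read, and two compounds give no number: the limit of > 250000 nM in this assay, at which 2 of the 4 values shown sit.

On these data alone, whether an amine or a carboxylic acid at this position would move the number the same way stays open. As far as these compounds go, it also stays open whether the step carries over to the fluoro compound 1 and the methyl compound 2.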